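Pyridyl ether series: amino in place of ethyl

This account rests on a few compounds, and the source may have more. Where it says the series, first, only, none or still open, it means among the compounds named here.

Two pyridyl ethers of the same N-methylpyrrolidinylmethoxy side chain have been measured in an assay on membranes from brain for displacement of a labelled ligand from Neuronal acetylcholine receptor; alpha4/beta2 (Rattus norvegicus); on this read-out higher numbers stand for weaker inhibition and lower numbers for stronger inhibition. Compound 1 `Cc1ncccc1OC[C@@H]1CCCN1C` gives 22.9 nM. Compound 2 `CCc1cncc(OC[C@@H]2CCCN2C)c1` gives 0.32 nM, the lowest of the two numbers; the gap to compound 1 lies beyond the scatter, so compound 2 is the stronger binder of the pair. Among the measured compounds shown here, no single-point step between measured compounds is available, and the two differ at more than one position, so the two values only show that compound 2 stands well ahead.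

Compound 3 `CN1CCC[C@H]1COc1cncc(N)c1` follows from compound 2 by amino in place of ethyl on an aromatic carbon. Nothing measured here shows how an amino group at that position behaves, so the expectation rests on compound 2 alone. A moderate weakening beyond the scatter is expected, a 4.7-fold higher number from compound 2 to compound 3 (0.67 log units; beyond the scatter). Compound 3 is estimated at 1.5 nM, with a range from 0.3 nM to 8 nM.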

Compound 3, inhibition constant: 0.63 nM
For compound 3 the middle estimate is 2.4-fold (0.38 log units) above the measured one, and the stated range covers the measured number.
By their numbers in this assay, from the lowest: compounds 2 and 3 (each within the scatter of the next); then compound 1.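

In this assay, amino in place of ethyl on an aromatic carbon, two atoms from the ring nitrogen, gives a 2.0-fold higher number from compound 2 to compound 3 (0.29 log units; within the scatter), so compound 2 and compound 3 cannot be told apart on this read-out. Among the compounds shown here, this is the first single-place step: at this position, the exchange of 2 heavy carbon atoms with 0 hydrogen-bond donors for 1 heavy nitrogen atom with 1 hydrogen-bond donor and 1 hydrogen-bond acceptor leaves the number within the scatter. No measurement at hand speaks to what lies behind this tolerance.

As far as these compounds go, whether the same position also accepts a carboxylic acid, a dimethylamino group or a longer chain such as propyl remains open. From the compounds shown here alone, compound 1 differs from compound 2 and compound 3 in more than one place, so the source of its gap also remains open.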